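Methylating a Selenium Handle on a Weak Cytotoxic Core

The compounds below may be only part of what the source reports. "The series", "measured", "known", "first", "only" and "open" are said of these compounds alone.

Compound 1, `Nc1nc([SeH])nc2ncccc12`, was tested in a functional assay on HT-29 cells (Homo sapiens) for cytotoxicity, read by MTT assay, with a stated time of 72 h; a higher number here means a weaker inhibitor of growth, a lower number a stronger inhibitor of growth. In this assay compound 1 gives 89600 nM, which is the only plain number among the three entries shown here. A related compound, compound 2, `[SeH]c1nc([SeH])c2cccnc2n1`, has no result in this assay: "not determined" (no result reported). Compound 3, `CSc1nc(NCc2ccccc2)c2ccccc2n1`, reaches only a limit of the assay, > 100000 nM, a limit described as the limit of > 100000 nM in this assay, at which 1 of the 3 values shown sits. No two of these compounds differ in just one place, so no measured step can be compared; compound 1 and compound 3 simply show a weak number next to a limit.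

The unmeasured compound 4, `C[Se]c1nc(N)c2cccnc2n1`, differs from compound 1 by methyl in place of hydrogen on a selenium. For the measured compounds named here, with no measured step of this kind to lean on, and with compound 1 already at 89600 nM, the change is expected to move the number little, in either direction, or not beyond the scatter. For compound 4 the expected value in this assay is 110000 nM, within a range of 40000 nM to 300000 nM. That estimate means a step of a 1.2-fold higher number from compound 1 to compound 4 (0.09 log units; within the scatter), and a limit rather than a number is a real possibility.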

Compound 4, concentration for total growth inhibition: 77300 nM
Compound 4: middle estimate off by 1.4-fold (0.15 log units), on the high side; the measured number falls inside the stated range.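

Methyl in place of hydrogen on a selenium gives a 1.2-fold lower number from compound 1 to compound 4 (0.06 log units; within the scatter) in this assay, the first step between two measured compounds that differ in one place. In this pair, then, the hydrogen on the selenium can be exchanged for methyl with no readable effect on growth inhibition, and the selenium position tolerates at least this smallest of carbon groups. Nothing measured here offers a reason for that result.

Going by these compounds, a single methyl cannot show how far this tolerance extends, so it remains open whether an ethyl group, a longer chain or a chain ending in a carboxylic acid on the same selenium would also leave the number within the scatter or would shift it clearly. With compound 2 lacking a result, the same question stays unanswered for a core carrying a second selenium.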